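This account rests on a few compounds, and the source may have more. Where it says the series, first, only, none or still open, it means among the compounds named here.

Compound 1 `CC(C)Sc1nnc(-c2c(CNC3CC3)c3ccccc3n2C)n1-c1ccccc1` gives 4.81 in a physicochemical assay for lipophilicity (on this read-out higher numbers stand for higher lipophilicity and lower numbers for lower lipophilicity), compound 2 `CC(C)Sc1nnc(-c2c(CNCC3CC3)c3ccccc3n2C)n1-c1ccccc1` gives 5.24, and compound 3 `CC(C)Sc1nnc(-c2c(CNc3cnccn3)c3ccccc3n2C)n1-c1ccccc1` gives 4.22, the lowest of the three numbers, with compound 1 nearest and compound 2 furthest. Compound 4 `COc1ccc(CNCc2c(-c3nnc(SC(C)C)n3-c3ccccc3)n(C)c3ccccc23)cc1` differs from compound 3 by 4-methoxybenzyl in place of pyrazin-2-yl on an amine nitrogen. For the measured compounds named here, two measured steps bear on this change, both running toward compound 3: a number 0.59 log units lower from compound 1 to compound 3 (beyond the scatter) and a number 1.02 log units lower from compound 2 to compound 3 (beyond the scatter). Replacing pyrazin-2-yl with 4-methoxybenzyl, a larger all-carbon aromatic group, is therefore expected to move this assay upward by at least the larger of these steps. Compound 4 is estimated at 5.7, within a range from 5.1 to 6.3, which corresponds to an expected step of a number 1.48 log units higher from compound 3 to compound 4 (beyond the scatter).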

Compound 4, partition coefficient: 6.27
Compound 4: the middle estimate sits 0.57 log units below what was measured; measured number inside the range.
By their numbers in this assay, from the lowest: compound 3; then compound 1; then compound 2; then compound 4.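

On the amine nitrogen, 4-methoxybenzyl gives the highest number of the four groups in this assay, and the change from pyrazin-2-yl is a number 2.05 log units higher from compound 3 to compound 4 (beyond the scatter). The new group also stands clear of both saturated groups: the steps are a number 1.46 log units higher from compound 1 to compound 4 (beyond the scatter) and a number 1.03 log units higher from compound 2 to compound 4 (beyond the scatter). Nothing available explains the size of these steps.

The compounds shown leave open how much of the rise belongs to the methoxy group and how much to the benzyl part. Plain benzyl on the same nitrogen would separate the two.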